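A few compounds are considered here, and "the series" means these few. Any claim that something is new, unique, unknown or untested is made for them only; others in the source may bear on it.

In a functional assay on HL-60 cells (Homo sapiens) for inhibition, read by MTT assay, with a stated time of 72 h, tested at 50 uM (on this read-out lower numbers stand for less inhibition of growth and higher numbers for more inhibition of growth at the one concentration tested), compound 1 (`C=CCc1cc(O)c(O)c(CN2CCC(C)CC2)c1`) gives 91.8%, compound 2 (`C=CCc1ccc(OCc2cn(-c3ccc(C#N)cc3)nn2)c(O)c1`) gives 31.8% and compound 3 (`C=CCc1ccc(OCc2cn(-c3cc(OC)c(OC)c(OC)c3)nn2)c(O)c1`) gives 41.4%. Compound 2 thus stands within the scatter of compound 3, while its gap to compound 1 lies beyond the scatter. Compound 4 (`C=CCc1ccc(OCc2cn(-c3ccccc3Cl)nn2)c(O)c1`) has 2-chlorophenyl in place of 4-cyanophenyl on an aromatic nitrogen. Going by the values given here, no measured pair shows this kind of change alone. Compound 3, with a different group on that nitrogen, gives 41.4%, so no step beyond the scatter is expected in this assay. The expected step of a number 4.2 percentage points higher from compound 2 to compound 4 (within the scatter) is small and slightly upward. For compound 4, the estimated value is 36%, with an expected range from 22% to 52%.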

Compound 4, percent growth inhibition at one concentration: 43.2%
Compound 4: middle estimate off by 7.2 percentage points, on the low side; low and high end bracket the measured number.
By their numbers in this assay, from the lowest: compounds 2, 3 and 4 (each within the scatter of the next, the first and the last beyond it); then compound 1.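

Going by these compounds alone, the change of 4-cyanophenyl to 2-chlorophenyl on an aromatic nitrogen gives the first readable step at this position: in this assay it is a number 11.4 percentage points higher from compound 2 to compound 4 (beyond the scatter) and shows that growth inhibition responds modestly to this group. Compound 4 still stands within the scatter of compound 3, which carries another group there. Nothing measured here accounts for the step.

The compounds shown leave open whether the step follows from gaining the chlorine or losing the nitrile. As far as these compounds go, how an unsubstituted phenyl or a benzyl group on that nitrogen would read also remains open.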